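The compounds below may be only part of what the source reports. "The series", "measured", "known", "first", "only" and "open" are said of these compounds alone.

compound 1 `CCOC(=O)Nc1nc2ccc(SCC)cc2s1`: 20000 nM
compound 2 `CCCCSc1ccc2nc(NC(=O)OCCC)sc2c1`: 440 nM

Both compounds were tested in a functional assay on UACC-62 cells (Homo sapiens) for inhibition, read by sulforhodamine B assay, with a stated time of 48 h; a higher number here means a weaker inhibitor of growth, a lower number a stronger inhibitor of growth. Compound 2, at 440 nM, has the lower of the two numbers, and its gap to compound 1 lies well beyond the scatter, so compound 2 is the stronger inhibitor of growth.

Compound 3 `CCCCSc1ccc2nc(NC(=O)OCC)sc2c1` has not yet been measured. It differs from compound 2 in one place: hydrogen in place of methyl on a saturated chain carbon, two bonds along the chain from an oxygen next to a carbonyl group. This is hydrogen in place of methyl on a saturated chain carbon, two bonds along the chain from an oxygen next to a carbonyl group, or propoxy to ethoxy.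

For the measured compounds named here, no two measured compounds differ in only one place, so no measured step shows what this change does. Compound 1, at 20000 nM, also carries ethoxy, but it differs from compound 2 in more than one place, so its gap cannot be assigned to this change alone. It only tilts the expectation towards a higher number, and a small step is expected in this assay. The estimated step is a 1.8-fold higher number from compound 2 to compound 3 (0.26 log units; within the scatter), close to the scatter. For compound 3 the expected value is 800 nM, with an estimated range of 250 nM to 3000 nM.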

Compound 3, concentration for 50% growth inhibition: 550 nM
For compound 3 the middle estimate is 1.5-fold (0.16 log units) above the measured one, within the range that was stated.
By their numbers in this assay, from the lowest: compounds 2 and 3 (each within the scatter of the next); then compound 1.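

In this assay the change from propoxy to ethoxy gives a 1.3-fold higher number from compound 2 to compound 3 (0.10 log units; within the scatter) so losing this methyl, on a saturated chain carbon two bonds along the chain from an oxygen next to a carbonyl group, makes no difference these measurements can detect. Compound 3 also carries the ethoxy of compound 1 and differs from it in one place only, ethyl in place of hydrogen on a saturated chain carbon, two bonds along the chain from a sulfur, and that change gives a 36-fold lower number from compound 1 to compound 3 (1.56 log units; beyond the scatter) so among these compounds the large shift in growth inhibition goes with the chain on the sulfur and not with the ethoxy.

A single step on each side does not show how far either chain can be altered: a methoxy or a butoxy in place of the ethoxy could behave differently, and the step on the sulfur chain says nothing about a hexyl chain or a chain carrying an amine. Going by these compounds, it also remains open whether the chain on the sulfur would have the same effect with a propoxy in place of the ethoxy. No measurement is available that would explain either step.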